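The compounds below may be only part of what the source reports. "The series", "measured", "known", "first", "only" and "open" are said of these compounds alone.

Measured so far in an assay on isolated protein for displacement of a labelled ligand from acyl-CoA:cholesterol acyltransferase (Oryctolagus cuniculus); a lower number here means a stronger inhibitor, a higher number a weaker inhibitor:
compound 1, `CC(C)c1cccc(C(C)C)c1NC(=O)Nc1nc2ccccc2n1-c1ccccc1Cl`: 18 nM
compound 2, `Cc1ccccc1-n1c(NC(=O)Nc2c(C(C)C)cccc2C(C)C)nc2ccccc21`: 19 nM
compound 3, `CC(C)c1cccc(C(C)C)c1NC(=O)Nc1nc2ccccc2n1-c1ccccc1C(F)(F)F`: 72 nM

Compound 3 gives the highest number of the three, and its gaps to compound 2 and to compound 1 are both beyond the scatter. Compound 4, `CC(C)c1cccc(C(C)C)c1NC(=O)Nc1nc2ccccc2n1-c1ccccc1O`, differs from compound 3 by hydroxy in place of trifluoromethyl on an aromatic carbon. Among the compounds with values here, no measured step introduces hydroxy at that position, so the guide is indirect: a 4.0-fold higher number from compound 1 to compound 3 (0.60 log units; beyond the scatter) and a 3.8-fold higher number from compound 2 to compound 3 (0.58 log units; beyond the scatter) were both modest and beyond the scatter, meaning that in the two cases on hand the trifluoromethyl analogue sits at the weaker end. A modest step towards a lower number is therefore expected, a 2.1-fold lower number from compound 3 to compound 4 (0.31 log units; beyond the scatter), with wide uncertainty. Compound 4 is estimated at 35 nM, range 10 nM to 130 nM.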

Compound 4, half-maximal inhibitory concentration: 200 nM
The estimate for compound 4 lay 5.7-fold (0.76 log units) below the measured number, outside the stated range (above it).
By their numbers in this assay, from the lowest: compounds 1 and 2 (each within the scatter of the next); then compound 3; then compound 4.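

Hydroxy is the first change at this position to give a large step: (an 11-fold higher number from compound 1 to compound 4 (1.05 log units; beyond the scatter)) and (an 11-fold higher number from compound 2 to compound 4 (1.02 log units; beyond the scatter)), whereas the earlier steps among chloro, methyl and trifluoromethyl were modest at most. Even trifluoromethyl, the weakest of the earlier three, does better than hydroxy (a 2.8-fold higher number from compound 3 to compound 4 (0.44 log units; beyond the scatter)), so this position does not accept every small group on the aromatic carbon equally. Nothing on hand explains the loss seen with hydroxy.

On these data alone, whether methoxy or an amine at this position would track with hydroxy remains open. So does whether the hydroxy loss would persist with a group other than the two isopropyl groups on the other aromatic ring.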